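The compounds below may be only part of what the source reports. "The series", "measured", "known", "first", "only" and "open" are said of these compounds alone.

Working notes on the series.

Compound 1 `CC(=O)N1CCC[C@H]1C(=O)OCC(F)F` and compound 2 `CCOC(=O)[C@@H]1CCCN1C(C)=O` share one core; compound 3 `OCCCC(F)(F)C(F)F` and compound 4 `CC(F)(F)CCCO` share another, and the difference between the two cores is not broken down here. In a physicochemical assay for lipophilicity, read by NMR (a lower number here means a more polar compound, a higher number a more lipophilic compound), compound 1 gives 0.02, and compound 2 gives 0, so the change methyl in place of difluoromethyl on a saturated chain carbon bound to an oxygen next to a carbonyl group gave a number 0.02 log units lower from compound 1 to compound 2 (within the scatter). Compound 3 gives 0.97 in this assay, the highest of the three numbers. The change methyl in place of difluoromethyl on a saturated chain carbon bound to two fluorine atoms and a saturated chain carbon is the same kind of change, but the place differs: in compound 1 the carbon is bound to an oxygen next to a carbonyl group, in compound 3 to two fluorine atoms and a saturated chain carbon. Beside the earlier step, a step of a number 0.17 log units lower from compound 3 to compound 4 (within the scatter) is expected from compound 3 to compound 4, resting on compound 1 and compound 2, whose step a number 0.02 log units lower from compound 1 to compound 2 (within the scatter) was flat, widened for the different place. Compound 4 is estimated at 0.8 in this assay, between 0.3 and 1.2.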

Compound 4, partition coefficient: 0.71
Compound 4: middle estimate off by 0.09 log units, on the high side; the measured number falls inside the stated range.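

In this assay the change to methyl in place of difluoromethyl gives a number 0.26 log units lower from compound 3 to compound 4 (within the scatter) and, on the core of compound 1, gives a number 0.02 log units lower from compound 1 to compound 2 (within the scatter) so on these two pairs the change stays inside the scatter on both cores. This does not show that the step carries over from one core to another in general: each core offers a single pair, the place of the change differs between them, and steps inside the scatter fix neither a size nor a direction. Nothing at hand bears on why either step came out as it did.

The compounds shown leave open how the same change reads in compounds holding an amine or a carboxylic acid, or on a longer chain.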